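A few compounds are considered here, and "the series" means these few. Any claim that something is new, unique, unknown or untested is made for them only; others in the source may bear on it.

Measured so far:

Compound 1 `Nc1cccc2c(-c3cccc(NC(=O)c4ccc5c(c4)OCCO5)c3)ccnc12`. In a functional assay on SK-MEL-2 cells (Homo sapiens) for antiproliferative activity, read by sulforhodamine B assay, with a stated time of 48 h (a higher number here means a weaker inhibitor, a lower number a stronger inhibitor), compound 1 reaches only a limit of the assay, > 20000 nM.
Compound 2 `COc1ccc(C(=O)Nc2cccc(-c3ccnc4c(NC(C)=O)cccc34)c2)cc1OC`. In this assay compound 2 gives 9400 nM.
Compound 3 `CC(=O)Nc1cccc2c(-c3cccc(NC(=O)c4ccc(Cl)c(C(F)(F)F)c4)c3)ccnc12`. In this assay compound 3 gives 3400 nM.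

Compound 3 therefore has the lowest of the two numbers that are real measurements, and its nearest neighbour is compound 2. Among the measured compounds shown here, the single step that connects two measured numbers is a 2.8-fold lower number from compound 2 to compound 3 (0.44 log units; beyond the scatter), in which an oxygen-bearing dimethoxyphenyl group on the amide carbonyl was exchanged for a chlorinated, trifluoromethylated phenyl group. Compound 4 `CC(=O)Nc1cccc2c(-c3cccc(NC(=O)c4ccc5c(c4)OCCO5)c3)ccnc12` is the next compound to be measured. Its change from compound 3 is 2,3-dihydro-1,4-benzodioxin-6-yl in place of 4-chloro-3-(trifluoromethyl)phenyl on a carbonyl carbon. For the measured compounds named here, this change runs in the opposite sense to the one measured step: the halogenated ring leaves and an oxygen-bearing ring resembling the dimethoxyphenyl of compound 2 enters. Compound 1 carries this same dihydrobenzodioxin amide, with an amino group on the core in place of acetamido, and gave only a limit. Going by the values given here, the expectation for compound 4 is therefore a step back upward of roughly the size of the one measured step, namely a 2.9-fold higher number from compound 3 to compound 4 (0.47 log units; beyond the scatter). Compound 4 is estimated at 10000 nM, within a range of 4000 nM to 25000 nM.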

Compound 4, half-maximal inhibitory concentration: > 20000 nM
Compound 4: a limit, no number; the forecaster's own chance of this, stated with the estimate: 30%; at least 2.0-fold (0.30 log units) between middle value and limit.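

With the acetamido core held the same, the group on the amide carbonyl clearly shapes the result in this assay: putting 2,3-dihydro-1,4-benzodioxin-6-yl in place of 4-chloro-3-(trifluoromethyl)phenyl gives an at least 5.8-fold higher number from compound 3 to compound 4 (0.76 log units; beyond the scatter). The two oxygen-bearing rings also turn out not to be interchangeable, since 2,3-dihydro-1,4-benzodioxin-6-yl in place of 3,4-dimethoxyphenyl gives an at least 2.1-fold higher number from compound 2 to compound 4 (0.32 log units; beyond the scatter), so closing the two oxygens into a ring does not preserve even the weak activity of compound 2. The step from compound 1 to compound 4 cannot be read, so the effect of the acetyl on the core nitrogen stays unknown, because compound 1 and compound 4 both stop at a limit rather than a number: the limit of > 20000 nM in this assay, at which 2 of the 4 values shown sit.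

Going by these compounds, it remains open whether the chlorine or the trifluoromethyl accounts for the lower number of compound 3, which a ring carrying only one of them, or a plain phenyl or pyridine ring, would help to settle. Also open, on these data alone, is how a free amino group on the core in place of acetamido would behave alongside 4-chloro-3-(trifluoromethyl)phenyl.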